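Amine substitution notes: from compound 3 to compound 4

The source may report more compounds than this note shows. Statements on the series, on what has been measured and on what is new or still open speak of the compounds shown alone.

Measured in a functional assay on MCF7 cells (Homo sapiens) for antiproliferative activity, read by MTT assay, with a stated time of 48 h; a higher number here means a weaker inhibitor, a lower number a stronger inhibitor:
- compound 1 `COc1ccc(C(=O)c2ccc(OC)c3c2OC(C)(C)C=C3)c(NC(=O)CN)c1`: 410 nM
- compound 2 `CNCC(=O)Nc1cc(OC)ccc1C(=O)c1ccc(OC)c2c1OC(C)(C)C=C2`: 820 nM
- compound 3 `CCNCC(=O)Nc1cc(OC)ccc1C(=O)c1ccc(OC)c2c1OC(C)(C)C=C2`: 5200 nM

Compound 3 carries the highest number of the three in this assay. The gaps to the other two are a 6.3-fold higher number from compound 2 to compound 3 (0.80 log units; beyond the scatter) and a 13-fold higher number from compound 1 to compound 3 (1.10 log units; beyond the scatter).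

The next structure is compound 4 `COc1ccc(C(=O)c2ccc(OC)c3c2OC(C)(C)C=C3)c(NC(=O)CN(C)C)c1`. The change is dimethylamino in place of ethylamino on a saturated chain carbon bound to a carbonyl carbon, with dimethylamino in place of ethylamino on a saturated chain carbon bound to a carbonyl carbon.

Within the data shown here, two measured steps bear on this most directly. Methyl in place of hydrogen on an amine nitrogen gave a 2.0-fold higher number from compound 1 to compound 2 (0.30 log units; within the scatter), which stays within the scatter. An ethyl group on the same nitrogen gave the large 13-fold higher number from compound 1 to compound 3 (1.10 log units; beyond the scatter). Among the measured compounds shown here, compound 4 has no ethyl group, but no measured compound shows the effect of a second methyl on that nitrogen, so the precedent is indirect. In this assay a modest move towards a lower number is therefore expected, a 2.9-fold lower number from compound 3 to compound 4 (0.46 log units; beyond the scatter). For compound 4 the estimate is 1800 nM, with an expected range of 600 nM to 5500 nM.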

Compound 4, half-maximal inhibitory concentration: 2680 nM
Estimate against measurement, compound 4: 1.5-fold (0.17 log units) below; measured number inside the range.
By their numbers in this assay, from the lowest: compounds 1 and 2 (each within the scatter of the next); then compounds 4 and 3 (each within the scatter of the next).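

Read in this assay, the second methyl on the amine nitrogen gives a 3.3-fold higher number from compound 2 to compound 4 (0.51 log units; beyond the scatter), which lies beyond the scatter, whereas the first methyl gave a 2.0-fold higher number from compound 1 to compound 2 (0.30 log units; within the scatter), which stayed within it. Replacing ethylamino with dimethylamino keeps the same heavy-atom count and removes the hydrogen-bond donor counted on ethylamino, yet gives only a 1.9-fold lower number from compound 3 to compound 4 (0.29 log units; within the scatter), so this position does not separate the two groups, and the step from amino to dimethylamino, a 6.5-fold higher number from compound 1 to compound 4 (0.82 log units; beyond the scatter), sits with a 13-fold higher number from compound 1 to compound 3 (1.10 log units; beyond the scatter) as a move beyond the scatter. Among these four compounds, the two groups carrying two carbons on the nitrogen therefore stand apart from amino and methylamino, though no measurement available here explains this.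

The compounds shown leave open whether diethylamino or a longer chain on this nitrogen would extend the trend towards higher numbers, or whether the two-carbon groups already mark its limit. They also leave open whether a hydroxy group on the saturated chain carbon bound to the carbonyl carbon, with no amine nitrogen at all, could stand in for amino.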